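Changing the aryl group on a level series

This account rests on a few compounds, and the source may have more. Where it says the series, first, only, none or still open, it means among the compounds named here.

Compound 1 `CN(C)C(=O)c1cc2cnc(Nc3ccc(NC(=O)C4(C(=O)Nc5ccc(F)cc5)CC4)cc3)nc2n1C1CCCC1`, compound 2 `CN(C)C(=O)c1cc2cnc(Nc3ccc(NC(=O)C4(C(=O)Nc5cccc(F)c5)CC4)cc3)nc2n1C1CCCC1` and compound 3 `Cc1ccc(NC(=O)C2(C(=O)Nc3ccc(Nc4ncc5cc(C(=O)N(C)C)n(C6CCCC6)c5n4)cc3)CC2)cc1` share one core and differ only in the aromatic group on an amide-type nitrogen. In a functional assay on SiHa cells (Homo sapiens) for inhibition, read by CCK-8 assay, with a stated time of 72 h, tested at 10 uM (a higher number here means more inhibition of growth at the concentration tested, a lower number less inhibition of growth), compound 1 gives 98%, compound 2 gives 107% and compound 3 gives 104%. The gaps from compound 3 to the other two lie within the scatter, so it stands level with both.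

Compound 4 `CN(C)C(=O)c1cc2cnc(Nc3ccc(NC(=O)C4(C(=O)Nc5cccc(Br)c5)CC4)cc3)nc2n1C1CCCC1` changes the same place: 3-bromophenyl in place of 4-methylphenyl on an amide-type nitrogen. One six-membered aromatic ring of carbon only leaves, and another enters. All three measured steps are swaps at this place: a number 9 percentage points higher from compound 1 to compound 2 (within the scatter), a number 6 percentage points higher from compound 1 to compound 3 (within the scatter) and a number 3 percentage points lower from compound 2 to compound 3 (within the scatter). For the measured compounds named here, none exceeds the scatter, but no measured compound carries a 3-bromophenyl group, so this guide is indirect. In this assay, no change beyond the scatter is therefore expected. The estimated change is a number 1 percentage points lower from compound 3 to compound 4 (within the scatter). For compound 4 the expected value is 103%, with an estimated range from 92% to 112%.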

Compound 4, percent growth inhibition at one concentration: 92.5%
The estimate for compound 4 lay 10.5 percentage points above the measured number; the measured number falls inside the stated range.
By their numbers in this assay, from the lowest: compounds 4, 1, 3 and 2 (each within the scatter of the next, the first and the last beyond it).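

Until now, every swap of the aromatic group on this amide-type nitrogen stayed within the scatter, but in this assay the new group gives a number 11.5 percentage points lower from compound 3 to compound 4 (beyond the scatter) and also a number 14.5 percentage points lower from compound 2 to compound 4 (beyond the scatter). So the group at this place can move the number, though only modestly, and not against every neighbour: the third comparison gives a number 5.5 percentage points lower from compound 1 to compound 4 (within the scatter), which leaves compound 4 level with compound 1. Nothing measured on these compounds offers a reason for the gaps to compound 2 and compound 3.

As far as these compounds go, whether a phenyl ring carrying an amine or a carboxylic acid, or a cyclohexyl group with no aromatic ring, would keep the number at this nitrogen stays open. Read at a single concentration, these numbers also leave open how the compounds would rank at lower concentrations.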